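Dropping the hydroxymethyl from the phenyl of compound 2

The compounds below may be only part of what the source reports. "The series", "measured", "known", "first", "only" and "open" are said of these compounds alone.

Measured compounds:
- compound 1 `CC(Sc1nc2nn(CC3COC3)cc2c(=O)n1-c1ccccc1)c1ccccc1`: 100 nM
- compound 2 `CC(Sc1nc2c(cnn2C)c(=O)n1-c1ccc(CO)cc1)c1ccccc1`: 600 nM
- compound 3 `O=c1c2cncn2nc(SCc2cccc(F)c2)n1-c1ccccc1`: 2200 nM

In an assay on isolated protein for inhibition of aldehyde dehydrogenase 1A1 (Homo sapiens) (a higher number here means a weaker inhibitor, a lower number a stronger inhibitor), compound 2 gives 600 nM, the second highest of the three numbers, beyond the scatter away from both compound 1 and compound 3. Compound 4 `CC(Sc1nc2c(cnn2C)c(=O)n1-c1ccccc1)c1ccccc1` is not yet measured. It differs from compound 2 in one place: hydrogen in place of hydroxymethyl on an aromatic carbon. Going by the values given here, no measured pair shows this difference alone, so its effect is unknown. Compound 1 carries a plain phenyl and gives the lowest number, but it also differs from compound 2 elsewhere. A modest step is expected, a 1.5-fold lower number from compound 2 to compound 4 (0.18 log units; within the scatter), toward a somewhat lower number. Compound 4 is expected to give about 400 nM, within a range from 150 nM to 1200 nM.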

Compound 4, half-maximal inhibitory concentration: 130 nM
Compound 4: the middle estimate sits 3.1-fold (0.49 log units) above what was measured; the measured number lies below the stated range.
By their numbers in this assay, from the lowest: compounds 1 and 4 (each within the scatter of the next); then compound 2; then compound 3.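

Swapping the hydroxymethyl for hydrogen gives the first clean reading of this place on the phenyl ring: in this assay the change gives a 4.6-fold lower number from compound 2 to compound 4 (0.66 log units; beyond the scatter). The hydroxymethyl is therefore not needed for inhibition on this core, and the plain phenyl gives the lower number. Nothing available explains this drop.

Going by these compounds, whether a methoxy, an amine or a carboxylic acid at the same place would lower or raise the number remains open. So does whether the hydroxymethyl would have the same effect on the cores of compound 1 and compound 3.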